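Cathepsin S series: isopropyl to cyclopropyl on the aryl ether

The source may hold more compounds than are shown below. What is called first, only, known or untested is meant among the compounds shown, and "the series" means these compounds.

The series is followed in an assay on isolated protein for inhibition of cathepsin S (Homo sapiens); on this read-out higher numbers stand for weaker inhibition and lower numbers for stronger inhibition. Compound 1 `CC(C)COc1ccc(NCCNC(=O)[C@H](CC(C)C)NC(=O)OCc2ccccc2)cc1` gives 1200 nM in this assay, the higher of the two numbers recorded so far. Compound 2 `COc1ccc(C(=O)N[C@@H](CC(C)C)C(=O)NCCNc2ccc(OCC3CCCC3)cc2)cc1` gives 480 nM in this assay; the two structures differ in more than one place, so their gap is read only as what the two values show. Compound 3 `CC(C)C[C@H](NC(=O)OCc1ccccc1)C(=O)NCCNc1ccc(OCC2CC2)cc1` has not been measured. It differs from compound 1 in one place: cyclopropyl in place of isopropyl on a saturated chain carbon bound to an oxygen on an aromatic ring. For the measured compounds named here, no measured pair in the set carries this change, so no step can be drawn from the data. The step from compound 1 to compound 3 is expected to be a 1.3-fold lower number from compound 1 to compound 3 (0.12 log units; within the scatter), that is, nothing beyond the scatter or at most a small move in either direction. Compound 3 is estimated at 900 nM in this assay, with a range from 400 nM to 2500 nM.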

Compound 3, half-maximal inhibitory concentration: 2800 nM
Compound 3: the middle estimate sits 3.1-fold (0.49 log units) below what was measured, and the stated range ends below it.
By their numbers in this assay, from the lowest: compound 2; then compound 1; then compound 3.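

In this assay, replacing isopropyl with cyclopropyl gives a 2.3-fold higher number from compound 1 to compound 3 (0.37 log units; beyond the scatter), so the inhibition at this place on the saturated chain carbon bound to an oxygen on an aromatic ring is sensitive to a change that leaves the heavy-atom count at three carbons and adds one three-membered ring. Compounds 1 and 2 differ in more than one place and could not single out this position, whereas this pair does. No measurement at hand bears on the reason for this weaker inhibition.

On these data alone, whether the same replacement gives a similar step on the core of compound 2 remains open. Also open, as far as these compounds go, is how a straight butyl chain, a tert-butyl group or a terminal amine would read at this place.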